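Changing the Amide Aryl Group: Compound 2 to Compound 4

The source may report more compounds than this note shows. Statements on the series, on what has been measured and on what is new or still open speak of the compounds shown alone.

Of the compounds shown here, three built on the shared core have been tested. In a functional assay on HeLa cells (Homo sapiens) for cytotoxicity, read by MTT assay, with a stated time of 24 h (a higher number here means a weaker inhibitor, a lower number a stronger inhibitor), compound 1 `C=CC1=C(C(=O)NCc2ccccc2)C(c2ccc(OC)cc2)OC1` gives only a limit, > 100000 nM. Compound 2 `C=CC1=C(C(=O)Nc2ccccc2OC)C(c2ccc(F)cc2)OC1` likewise stops at a limit, > 100000 nM. Compound 3 `C=CC1=C(C(=O)Nc2ccccc2OC)C(c2ccc(Cl)c(Cl)c2)OC1` also reaches only a limit, > 100000 nM. The step that the two limits leave unreadable from compound 2 to compound 3 cannot be read, since (the limit of > 100000 nM in this assay, at which 3 of the 3 values shown sit). Compound 2 thus stands at the same limit as the other two, with no number of its own. Compound 4 `C=CC1=C(C(=O)Nc2ccc(C)cc2)C(c2ccc(F)cc2)OC1` differs from compound 2 by 4-methylphenyl in place of 2-methoxyphenyl on an amide-type nitrogen. For the measured compounds named here, no measured step touches the amide nitrogen, and the single measured step has no readable size. Compound 4 is therefore expected to remain near the limit, with an estimate of 120000 nM between 30000 nM and 500000 nM. The expected step that the limit leaves unreadable from compound 2 to compound 4 is accordingly none beyond the scatter.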

Compound 4, half-maximal inhibitory concentration: > 100000 nM
Compound 4 gave a limit, no number (the forecaster's own chance of this, stated with the estimate: 80%); the middle value does not contradict the limit.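

No new step can be read between compound 2 and compound 4, since each stops at a limit: the limit of > 100000 nM in this assay, at which 4 of the 4 values shown sit.
The compounds shown leave open whether any change on the shared core brings a measurable value in this assay at all.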